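The compounds below may be only part of what the source reports. "The series", "measured", "known", "first", "only" and "open" are said of these compounds alone.

Working notes on the series. Compound 1 `Cc1ccc(COc2ccc(C(=O)NC(=S)Nc3ccc(C)c(-c4nc5ccccc5[nH]4)c3)cc2)cc1` gives 14200 nM in a functional assay on HT-29 cells (Homo sapiens) for inhibition, read by MTT assay, with a stated time of 48 h; a higher number here means a weaker inhibitor, a lower number a stronger inhibitor. Among the measured compounds shown here, compound 2 `Cc1ccc(NC(=S)NC(=O)c2ccc(OCc3cccc(F)c3)cc2)cc1-c1nc2ccccc2[nH]1` gives 55300 nM in this assay and stands with the highest of the two numbers so far; the only step to it, a 3.9-fold higher number from compound 1 to compound 2 (0.59 log units; beyond the scatter), is the sole measured change at this position. Compound 3 `Cc1ccc(NC(=S)NC(=O)c2ccc(OCc3ccc(Cl)c(Cl)c3)cc2)cc1-c1nc2ccccc2[nH]1` is still to be measured. It differs from compound 2 only as 3,4-dichlorophenyl in place of 3-fluorophenyl on a saturated chain carbon bound to an oxygen on an aromatic ring. For the measured compounds named here, no measured step exchanges one halogenated aryl for another at this place; the single step from compound 1 to compound 2 shows only that changing the aryl on this saturated chain carbon can move the number by a modest amount in either direction. The step from compound 2 to compound 3 is therefore expected to be small, close to the scatter, at a 1.6-fold lower number from compound 2 to compound 3 (0.20 log units; within the scatter). For compound 3 the estimate in this assay is 35000 nM, with a range from 9000 nM to 130000 nM.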

Compound 3, half-maximal inhibitory concentration: 6270 nM
Estimate against measurement, compound 3: 5.6-fold (0.75 log units) above; the whole stated range lies above it.
By their numbers in this assay, from the lowest: compound 3; then compound 1; then compound 2.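

In this assay, exchanging one halogenated aryl for another on a saturated chain carbon bound to an oxygen on an aromatic ring is not a small change: 3,4-dichlorophenyl in place of 3-fluorophenyl gives an 8.8-fold lower number from compound 2 to compound 3 (0.95 log units; beyond the scatter). The same group also improves on the 4-methylphenyl, with a 2.3-fold lower number from compound 1 to compound 3 (0.36 log units; beyond the scatter), so this position now shows movement in both directions, and compound 3 holds the lowest number of the three, with its steps to both others beyond the scatter. Nothing available bears on the reason for these steps.

The compounds shown leave open whether a single chlorine on the phenyl would give the same step as the two in compound 3. They also leave open how an amine or a carboxylic acid on this aryl would read.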